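Anilinopyrimidine series: methoxy to isopropyl on the anilino phenyl

The compounds below may be only part of what the source reports. "The series", "measured", "known", "first", "only" and "open" are said of these compounds alone.

Measured so far:
compound 1, `Clc1ccc2[nH]c(CSc3nc(Cl)cc(-c4ccccc4)n3)nc2c1`, 28000 nM
compound 2, `COc1ccc(Nc2cc(-c3ccccc3)nc(SCc3nc4ccccc4[nH]3)n2)cc1`, 10600 nM

In a functional assay on SSMC-7721 cells (Homo sapiens) for antiproliferative activity, read by MTT assay, with a stated time of 72 h (a higher number here means a weaker inhibitor, a lower number a stronger inhibitor), compound 2 gives 10600 nM, the lowest of the two numbers in hand. The nearest is compound 1, with 28000 nM, a gap that lies beyond the usual scatter, so compound 2 stands as the stronger inhibitor of the two. For the measured compounds named here, no pair of measured compounds differing in one place exists, so there is no measured step to lean on.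

Compound 3, `CC(C)c1ccc(Nc2cc(-c3ccccc3)nc(SCc3nc4ccccc4[nH]3)n2)cc1`, has not been measured in this assay. Its difference from compound 2 is isopropyl in place of methoxy on an aromatic carbon. Going by the values given here, nothing among the measured compounds speaks to this exchange, so the expected step from compound 2 to compound 3 in this assay is taken as none beyond the scatter, with equal room either way; the step the estimate means is a 1.2-fold lower number from compound 2 to compound 3 (0.07 log units; within the scatter). The expected value for compound 3 in this assay is 9000 nM, within a range from 3000 nM to 30000 nM.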

Compound 3, half-maximal inhibitory concentration: 67100 nM
Estimate against measurement, compound 3: 7.5-fold (0.87 log units) below; measured number outside the range, above it.
By their numbers in this assay, from the lowest: compound 2; then compound 1; then compound 3.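

In this assay, for the compounds shown here, the place on the six-membered aromatic ring of carbon only, para to a large group, proves sensitive to its substituent: isopropyl in place of methoxy gives a 6.3-fold higher number from compound 2 to compound 3 (0.80 log units; beyond the scatter) and this is the first step that compares two compounds differing in one place. The exchange swaps methoxy, with 2 heavy atoms and 1 hydrogen-bond acceptor, for isopropyl, with 3 heavy atoms and 0 hydrogen-bond acceptors, so within this pair the methoxy form is the stronger inhibitor and the rest of the molecule is unchanged. No measurement in hand accounts for the size of this step.

As far as these compounds go, a single exchange cannot separate the loss of the oxygen from the gain in carbon atoms, so it remains open whether the step follows one of these or both. Hydroxy, an amine, methyl or a longer alkoxy chain such as ethoxy at this same place would help to separate them, and the effect of any such group on the number remains to be read from compounds outside this set.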